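Chloro for hydroxy on the shared core

A few compounds are considered here, and "the series" means these few. Any claim that something is new, unique, unknown or untested is made for them only; others in the source may bear on it.

Compound 1 `Oc1ccc2cc3c(cc2n1)C1CNCC3C1` gives 8.5 nM in an assay for binding affinity to Neuronal acetylcholine receptor; alpha4/beta2 (Rattus norvegicus) (on this read-out higher numbers stand for weaker inhibition and lower numbers for stronger inhibition), the lowest of the two numbers recorded. Compound 2 `Clc1ccc(-c2cnc3cc4c(cc3n2)C2CNCC4C2)c(Cl)c1` gives 88 nM in this assay, a gap from compound 1 beyond the scatter. Compound 3 `Clc1ccc2cc3c(cc2n1)C1CNCC3C1` is not yet measured. It differs from compound 1 by chloro in place of hydroxy on an aromatic carbon. For the measured compounds named here, no step between measured compounds covers this change, so the expectation rests on compound 1 alone. The step from compound 1 to compound 3 is expected to be small, within the scatter, as a 1.4-fold lower number from compound 1 to compound 3 (0.15 log units; within the scatter). For compound 3 the estimate in this assay is 6 nM, expected between 1.5 nM and 25 nM.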

Compound 3, inhibition constant: 0.27 nM
Compound 3: middle estimate off by 22-fold (1.35 log units), on the high side; the measured number lies below the stated range.
By their numbers in this assay, from the lowest: compound 3; then compound 1; then compound 2.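

In this assay, chloro in place of hydroxy on the aromatic carbon next to the ring nitrogen gives a 31-fold lower number from compound 1 to compound 3 (1.50 log units; beyond the scatter), so this position on the shared core responds strongly to the group it carries. The low number of compound 3 also shows that a hydrogen-bond donor or acceptor on this atom is not required for strong inhibition here. No measurement at hand accounts for the size of this step. As far as these compounds go, whether fluoro, methoxy or an amine at this position would match chloro remains open. This single pair also leaves open whether the step would recur on another core.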